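Nitrone-bearing triazoles with alkyl chains: notes on cell growth

The source may hold more compounds than are shown below. What is called first, only, known or untested is meant among the compounds shown, and "the series" means these compounds.

Measured so far:
compound 1 `CCCCCCCCCCn1cc(/C=[N+](\[O-])c2ccccc2)nn1` — > 100000 nM
compound 2 `CCCCCCCCn1cc(/C=[N+](\[O-])C(C)(C)C)nn1` — 24600 nM

Two compounds have been run in a functional assay on PC-3 cells (Homo sapiens) for inhibition, read by MTT assay, with a stated time of 24 h; on this read-out lower numbers stand for stronger inhibition and higher numbers for weaker inhibition. Compound 1 `CCCCCCCCCCn1cc(/C=[N+](\[O-])c2ccccc2)nn1` reaches only a limit of the assay, > 100000 nM; this is the limit described in the limit of > 100000 nM in this assay, at which 1 of the 2 values shown sits, and gives no number. Going by the values given here, compound 2 `CCCCCCCCn1cc(/C=[N+](\[O-])C(C)(C)C)nn1` is therefore the only compound with a number, 24600 nM, and it stands alone as the sole fixed point of the series; no step between two measured compounds can be drawn from it.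

Compound 3 `CCCCCCCCCCn1cc(/C=[N+](\[O-])C(C)(C)C)nn1` has not yet been measured. It differs from compound 2 by ethyl in place of hydrogen on a saturated chain carbon, eight bonds along the chain from an aromatic nitrogen, so that the chain grows at its far end while the tert-butyl nitrone side is kept. With no measured step of this kind in hand, the expectation for this assay is a change of no more than the usual scatter, in either direction. Compound 3 is thus estimated at 22000 nM, between 8000 nM and 65000 nM, which would mean an expected step of a 1.1-fold lower number from compound 2 to compound 3 (0.05 log units; within the scatter).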

Compound 3, half-maximal inhibitory concentration: 19800 nM
Compound 3: the middle estimate sits 1.1-fold (0.05 log units) above what was measured, within the range that was stated.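

In this assay, the chain position now has its first measured step, a 1.2-fold lower number from compound 2 to compound 3 (0.09 log units; within the scatter): ethyl in place of hydrogen on a saturated chain carbon, eight bonds along the chain from an aromatic nitrogen, leaves the read-out within the scatter for this pair with the tert-butyl nitrone side kept. Going by these compounds alone, the change on the other side of the shared core gives the first step beyond the scatter, an at least 5.0-fold lower number from compound 1 to compound 3 (0.70 log units; beyond the scatter), with tert-butyl in place of phenyl on a double-bonded nitrogen and the chain kept. Compound 1 gives a limit and no number, so the size of this step is a lower bound only: the limit of > 100000 nM in this assay, at which 1 of the 3 values shown sits.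

One pair of chain lengths says little about the chain as a whole, and a much shorter butyl chain or a longer dodecyl chain on the same tert-butyl nitrone would show whether the flat step holds beyond compound 2 and compound 3. Only phenyl and tert-butyl are shown on the double-bonded nitrogen, so it remains open where a cyclohexyl or a benzyl group there would fall.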